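Benzyl halogen swap in a series sitting at the assay limit

The compounds below may be only part of what the source reports. "The series", "measured", "known", "first", "only" and "open" are said of these compounds alone.

Measured compounds, read in a functional assay on SW480 cells (Homo sapiens) for cytotoxicity, read by MTT assay, with a stated time of 48 h; on this read-out higher numbers stand for weaker inhibition and lower numbers for stronger inhibition:
Compound 1 `O=c1ccoc2cc(OCc3cn(Cc4cccc(F)c4)nn3)ccc12` gives > 100000 nM, a limit of the assay.
Compound 2 `Cc1ccccc1Cn1cc(COc2ccc3c(=O)ccoc3c2)nn1` gives > 100000 nM, a limit of the assay.
Compound 3 `O=c1ccoc2cc(OCc3cn(Cc4ccc(Cl)cc4)nn3)ccc12` gives > 100000 nM, a limit of the assay.

Compound 3 stands, like the other two, only at a limit of this assay and not at a number; (the limit of > 100000 nM in this assay, at which 3 of the 3 values shown sit). The steps that connect the measured compounds are therefore not readable in size: a step that the two limits leave unreadable from compound 1 to compound 2, a step that the two limits leave unreadable from compound 1 to compound 3, and a step that the two limits leave unreadable from compound 2 to compound 3. None of them tells whether the benzyl group moves the read-out at all.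

Compound 4 `O=c1ccoc2cc(OCc3cn(Cc4ccc(F)cc4)nn3)ccc12` is the next member. It differs from compound 3 by fluoro in place of chloro on an aromatic carbon. For the measured compounds named here, the three unreadable steps are the only evidence bearing on this change, and none of them gives a direction or a size. With every shown value at the limit, no step beyond the scatter is expected in this assay; the expected step of a number no higher from compound 3 to compound 4 (the limit leaves the size open) is only nominal. Compound 4 is thus expected to remain at the limit as well, estimated at 100000 nM with a range from 50000 nM to 300000 nM.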

Compound 4, half-maximal inhibitory concentration: 11200 nM
The estimate for compound 4 lay 8.9-fold (0.95 log units) above the measured number; measured number outside the range, below it.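

In this assay, for the compounds shown here, the change from chloro to fluoro on an aromatic carbon, para to a large group, gives the first number rather than a limit: an at least 8.9-fold lower number from compound 3 to compound 4 (0.95 log units; beyond the scatter). The place of the fluoro also matters, since 4-fluorophenyl in place of 3-fluorophenyl gives an at least 8.9-fold lower number from compound 1 to compound 4 (0.95 log units; beyond the scatter), while 4-fluorophenyl in place of 2-methylphenyl gives an at least 8.9-fold lower number from compound 2 to compound 4 (0.95 log units; beyond the scatter). These three steps have only a minimum size, and the steps among compound 1, compound 2 and compound 3 still cannot be read: the limit of > 100000 nM in this assay, at which 3 of the 4 values shown sit.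

Going by these compounds, with a single number, the true size of each step stays open. Also open, on these data alone, is whether a methoxy group or an amine in the place of the fluoro would give a number or stay at the limit.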